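The source may report more compounds than this note shows. Statements on the series, on what has been measured and on what is new or still open speak of the compounds shown alone.

Measured in a functional assay on LOX IMVI cells (Homo sapiens) for cytotoxicity, read by MTT assay, with a stated time of 24 h; on this read-out higher numbers stand for weaker inhibition and lower numbers for stronger inhibition:

- compound 1 `COc1cc(-c2nc(-c3ccccc3)[nH]c2-c2ccnc(NCCCNS(=O)(=O)c3ccc(C)cc3)n2)ccc1Cl`: 18600 nM
- compound 2 `COc1ccc(S(=O)(=O)NCCCNc2nccc(-c3[nH]c(-c4ccccc4)nc3-c3ccc(Cl)c(OC)c3)n2)cc1`: 1800 nM
- compound 3 `COc1cc(-c2nc(-c3ccccc3)[nH]c2-c2ccnc(NCCCNS(=O)(=O)c3cccc4ccccc34)n2)ccc1Cl`: 13500 nM

Compound 1 stands at the high end of these numbers, level with compound 3 within the scatter: a 1.4-fold lower number from compound 1 to compound 3 (0.14 log units; within the scatter). Compound 4 `Cc1ccc(S(=O)(=O)NCCCNc2nccc(-c3[nH]c(-c4ccccc4)nc3-c3ccc(F)c(O)c3)n2)cc1` differs from compound 1 as follows: 4-fluoro-3-hydroxyphenyl in place of 4-chloro-3-methoxyphenyl on an aromatic carbon. The exchange sits on an aromatic carbon of a five-membered aromatic ring with 2 nitrogen. Within the data shown here, no measured step touches this place. The steps available all concern the group on the sulfonyl sulfur: a 10-fold lower number from compound 1 to compound 2 (1.01 log units; beyond the scatter), and a 7.5-fold higher number from compound 2 to compound 3 (0.88 log units; beyond the scatter). They show that the series can move, but they give no direction here, so no step beyond the scatter is expected in this assay. The expected change is a 1.7-fold lower number from compound 1 to compound 4 (0.23 log units; within the scatter). For compound 4 the estimated value is 11000 nM, with an expected range of 3000 nM to 30000 nM.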

Compound 4, half-maximal inhibitory concentration: 26300 nM
Compound 4: middle estimate off by 2.4-fold (0.38 log units), on the low side; the range from low to high includes it.
By their numbers in this assay, from the lowest: compound 2; then compounds 3, 1 and 4 (each within the scatter of the next).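

Among these compounds, the exchange of 4-chloro-3-methoxyphenyl for 4-fluoro-3-hydroxyphenyl on the five-membered ring gives a 1.4-fold higher number from compound 1 to compound 4 (0.15 log units; within the scatter) and so offers the first reading at this position, one that stays within the scatter. The change adds a hydrogen-bond donor and replaces chlorine with fluorine in a single step, and these parts cannot be separated here. No measurement bears on why the number stayed level.

Still open, as far as these compounds go, is whether a 3-aminophenyl or a 3-carboxyphenyl group at this position would move the number. Also open, from the compounds shown here alone, is whether 4-fluoro-3-hydroxyphenyl behaves the same alongside the 4-methoxyphenyl group on the sulfonyl sulfur.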